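The source may hold more compounds than are shown below. What is called first, only, known or untested is meant among the compounds shown, and "the series" means these compounds.

compound 1 `CCCCCCn1cnc2c(Nc3ccc(Cl)cc3)nc(N[C@H]3CC[C@H](N)CC3)nc21` gives 5500 nM
compound 2 `CCCCCCn1cnc2c(Nc3cc(OC)cc(OC)c3)nc(N[C@H]3CC[C@H](N)CC3)nc21` gives 3700 nM
compound 3 `CCCCCCn1cnc2c(Nc3cccc(Cl)c3)nc(N[C@H]3CC[C@H](N)CC3)nc21` gives 5100 nM

These three numbers come from a functional assay on BT-474 cells (Homo sapiens) for inhibition, read by fluorescence, with a stated time of 72 h; a lower number here means a stronger inhibitor of growth, a higher number a weaker inhibitor of growth. Compound 3 cannot be ranked against either of the others, since the steps to it are a 1.1-fold lower number from compound 1 to compound 3 (0.03 log units; within the scatter) and a 1.4-fold higher number from compound 2 to compound 3 (0.14 log units; within the scatter). The remaining step, a 1.5-fold lower number from compound 1 to compound 2 (0.17 log units; within the scatter), tells the same story. All three steps exchange the substituted phenyl group on a nitrogen and leave the hexyl chain untouched.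

Compound 4 `N[C@H]1CC[C@H](Nc2nc(Nc3cccc(Cl)c3)c3ncn(Cc4ccccc4)c3n2)CC1` keeps the 3-chlorophenyl of compound 3 and alters that chain instead: phenyl in place of pentyl on a saturated chain carbon bound to an aromatic nitrogen. This is phenyl in place of pentyl on a saturated chain carbon bound to an aromatic nitrogen, or hexyl to benzyl when cut one bond further out. For the measured compounds named here, no measured step touches this place, so the data give no direct size or direction for the change. The flat steps seen elsewhere on the molecule are only a weak guide, and the range must stay wide. The starting point is compound 3 at 5100 nM, and no clear shift in this assay is expected. The expected change is a 1.2-fold higher number from compound 3 to compound 4 (0.07 log units; within the scatter). For compound 4 the estimated value is 6000 nM, with an expected range of 2000 nM to 18000 nM.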

Compound 4, concentration for 50% growth inhibition: 10200 nM
The estimate for compound 4 lay 1.7-fold (0.23 log units) below the measured number; the range from low to high includes it.
By their numbers in this assay, from the lowest: compounds 2, 3, 1 and 4 (each within the scatter of the next, the first and the last beyond it).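

In this assay the exchange of hexyl for benzyl gives a 2.0-fold higher number from compound 3 to compound 4 (0.30 log units; within the scatter) and this is the only step shown at this place, on a saturated chain carbon bound to an aromatic nitrogen. The earlier compounds shown here varied only the substituted phenyl group on a nitrogen, so this step adds something new: an open chain can give way to a six-membered aromatic ring of carbon only, and the result still cannot be told apart from compound 3 in this measurement. Every step shown so far, at either place, now lies within the scatter, and no measurement here offers a reason for this result.

As far as these compounds go, one pair cannot show how much this place matters in general, so it stays open whether a chain ending in an amine or a carboxylic acid, or a much shorter chain such as ethyl, would move the number beyond the scatter. From the compounds shown here alone, it is also open whether hexyl and benzyl would still match if the 3-chlorophenyl group were replaced by another group, such as the 3,5-dimethoxyphenyl of compound 2.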